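The source may hold more compounds than are shown below. What is called first, only, known or untested is meant among the compounds shown, and "the series" means these compounds.

Working notes on the series. Compound 1 `O=C(Nc1ccc(Oc2ccnc3[nH]ccc23)c(F)c1)c1nn(-c2ccc(Br)cc2)ccc1=O` and compound 2 `O=C(Nc1ccc(Oc2ccnc3[nH]ccc23)c(F)c1)c1nn(-c2ccccc2)ccc1=O` share one core; compound 3 `Cn1ccc2c(Oc3ccc(NC(=O)c4nn(-c5ccc(Br)cc5)ccc4=O)cc3)ccnc21` and compound 4 `Cn1ccc2c(Oc3ccc(NC(=O)c4nn(-c5ccccc5)ccc4=O)cc3)ccnc21` share another, and the difference between the two cores is not broken down here. In a functional assay on A549 cells (Homo sapiens) for cytotoxicity, read by MTT assay, with a stated time of 72 h (on this read-out higher numbers stand for weaker inhibition and lower numbers for stronger inhibition), compound 1 gives > 60000 nM, which is a limit of the assay and not a number (the limit of > 60000 nM in this assay, at which 1 of the 3 values shown sits). In this assay compound 2 gives 56800 nM, and compound 3 gives 59400 nM; these two values sit within the scatter of each other. The change from compound 1 to compound 2 is hydrogen in place of bromo on an aromatic carbon, and it made an at least 1.0-fold lower number from compound 1 to compound 2 (0.02 log units; that floor lies within the scatter). The change from compound 3 to compound 4 is hydrogen in place of bromo on an aromatic carbon, the same change at the same kind of place. For the measured compounds named here, because the measured step was an at least 1.0-fold lower number from compound 1 to compound 2 (0.02 log units; that floor lies within the scatter), a step of similar size is expected on the second core, resting on the one pair measured. Compound 4 is therefore expected to give about 55000 nM in this assay. That expectation means a step of a 1.1-fold lower number from compound 3 to compound 4 (0.03 log units; within the scatter), with a real chance that only a limit is returned.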

Compound 4, half-maximal inhibitory concentration: 51700 nM
Compound 4: middle estimate off by 1.1-fold (0.03 log units), on the high side; the measured number falls inside the stated range.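

In this assay, 4-bromophenyl to phenyl on the core of compound 3 gave a 1.1-fold lower number from compound 3 to compound 4 (0.06 log units; within the scatter), so on this core the change left no step beyond the scatter. Set beside the first core, the change reads as follows: the same change on two cores in this assay, an at least 1.0-fold lower number (0.02 log units; that floor lies within the scatter) from compound 1 to compound 2 and a 1.1-fold lower number (0.06 log units; within the scatter) from compound 3 to compound 4; the limit leaves it open whether they differ. Compound 1 gives > 60000 nM, which is a limit of the assay and not a number, so the pair shows that the second step fits the floor of the first but does not show that the change carries over with the same size: the limit of > 60000 nM in this assay, at which 1 of the 4 values shown sits.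

The compounds shown leave open whether another group in place of bromo at the same place, such as an amine or a carboxylic acid, would give a step beyond the scatter in this assay on either core. They also leave open how large the step on the core of compound 1 really is, as its bromo member gives only a limit.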